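Swapping cyclopentyl for phenyl on the side chain

A few compounds are considered here, and "the series" means these few. Any claim that something is new, unique, unknown or untested is made for them only; others in the source may bear on it.

In a functional assay on MV4-11 cells (Homo sapiens) for antiproliferative activity, read by CellTiter-Glo, with a stated time of 72 h (a lower number here means a stronger inhibitor of growth, a higher number a weaker inhibitor of growth), three compounds share a core and differ in the ring on one side chain. Compound 1 `COCCN[C@H]1CC[C@H](Nc2cc(-c3csc(NCC4CCOCC4)n3)c(Cl)cn2)CC1` carries oxan-4-yl and reads 170 nM here. Compound 2 `COCCN[C@H]1CC[C@H](Nc2cc(-c3csc(NCC4CC4)n3)c(Cl)cn2)CC1` carries cyclopropyl and reads 740 nM here. Compound 3 `COCCN[C@H]1CC[C@H](Nc2cc(-c3csc(NCC4CCCC4)n3)c(Cl)cn2)CC1` carries cyclopentyl and sits at 2160 nM as the weakest inhibitor of the three, with both of its gaps beyond the usual scatter.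

Compound 4 `COCCN[C@H]1CC[C@H](Nc2cc(-c3csc(NCc4ccccc4)n3)c(Cl)cn2)CC1` has not been measured. It differs from compound 3 as follows phenyl in place of cyclopentyl on a saturated chain carbon bound to a nitrogen on an aromatic ring and in words this is phenyl in place of cyclopentyl on a saturated chain carbon bound to a nitrogen on an aromatic ring. No aromatic ring has been tested at this place, so the evidence is indirect. Three measured ring swaps at this place bear on it. The first is a 4.4-fold higher number from compound 1 to compound 2 (0.64 log units; beyond the scatter) and the second is a 13-fold higher number from compound 1 to compound 3 (1.10 log units; beyond the scatter) while the third is a 2.9-fold higher number from compound 2 to compound 3 (0.47 log units; beyond the scatter) and each lies beyond the scatter.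

Compound 3 stands at 2160 nM with both other rings giving lower numbers, and on that ground a modest step down in this assay is expected. The estimated change is a 2.7-fold lower number from compound 3 to compound 4 (0.43 log units; beyond the scatter) and a step the other way cannot be excluded. For compound 4 the expected value is 800 nM with an estimated range of 250 nM to 2500 nM for now.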

Compound 4, concentration for 50% growth inhibition: 330 nM
For compound 4 the middle estimate is 2.4-fold (0.38 log units) above the measured one; the range from low to high includes it.
By their numbers in this assay, from the lowest: compounds 1 and 4 (each within the scatter of the next); then compound 2; then compound 3.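

In this assay, phenyl, the first aromatic ring at this place, gives a 6.5-fold lower number from compound 3 to compound 4 (0.82 log units; beyond the scatter) and also a 2.2-fold lower number from compound 2 to compound 4 (0.35 log units; beyond the scatter), so an aromatic ring on this saturated chain carbon is compatible with some of the lowest numbers in the set. Against the oxan-4-yl of the best earlier compound, the step is a 1.9-fold higher number from compound 1 to compound 4 (0.29 log units; within the scatter), so the two cannot be ranked, and a ring of carbon only can match oxan-4-yl here, which the weak cyclopentyl compound gave no sign of. Phenyl and cyclopentyl are both rings of carbon only and yet sit far apart, so carbon-only composition does not settle the number, and no supporting measurement is available to explain the gap between them.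

The compounds shown leave open whether a pyridine ring in place of phenyl, or a fluorine or methoxy group on the phenyl ring, would lower the number further. They also leave open how a longer chain, such as phenylethyl in place of benzyl, would read in this assay.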